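Vinyl sulfide ketone series: growth inhibition of DU-145 cells

The source may hold more compounds than are shown below. What is called first, only, known or untested is meant among the compounds shown, and "the series" means these compounds.

Measured so far in a functional assay on DU-145 cells (Homo sapiens) for inhibition, read by trypan blue exclusion, with a stated time of 96 h; a higher number here means a weaker inhibitor of growth, a lower number a stronger inhibitor of growth:
compound 1, `COc1ccc(/C=C(/Sc2ccc(C)cc2)C(=O)c2ccc(Br)cc2)cc1`, gives 50000 nM;
compound 2, `Cc1ccc(S/C(=C/c2ccc(-c3ccccc3)cc2)C(=O)c2ccc(Br)cc2)cc1`, gives 50000 nM;
compound 3, `COc1ccc(/C=C(/Sc2ccc(C)cc2)C(=O)c2ccc(Cl)cc2)cc1`, gives 1000 nM.

Compound 4, `Cc1ccc(S/C(=C/c2ccc(-c3ccccc3)cc2)C(=O)c2ccc(Cl)cc2)cc1`, remains to be measured in this assay.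

Compound 4 differs from compound 3 by phenyl in place of methoxy on an aromatic carbon. The same change is already on record between compound 1 and compound 2, as phenyl in place of methoxy on an aromatic carbon, and its step there was no change at the digits printed from compound 1 to compound 2 (within the scatter). The two pairs sit on different cores: the core of compound 3 differs from the core of compound 1 by chloro in place of bromo on an aromatic carbon, and that core change alone made a step of a 50-fold lower number from compound 1 to compound 3 (1.70 log units; beyond the scatter).

Among the measured compounds shown here, the expectation for compound 4 rests on the one earlier instance of the change, compound 1 to compound 2, whose step no change at the digits printed from compound 1 to compound 2 (within the scatter) showed nothing beyond the scatter. On that ground the step from compound 3 to compound 4 in this assay is estimated at a 2.0-fold higher number from compound 3 to compound 4 (0.30 log units; within the scatter). The caveat is that compound 1 and compound 2 both sit at a high number, where a real shift may not show, so the range is kept wide. Compound 4 is accordingly estimated at 2000 nM, between 500 nM and 20000 nM.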

Compound 4, concentration for 50% growth inhibition: 50000 nM
Compound 4: the middle estimate sits 25-fold (1.40 log units) below what was measured; measured number above the stated range.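

In this assay, phenyl in place of methoxy on an aromatic carbon gives a 50-fold higher number from compound 3 to compound 4 (1.70 log units; beyond the scatter) on the chloro core, but nothing beyond the scatter on the bromo core, so the step does not carry from one core to the other: the same change on two cores in this assay, no change at the digits printed (within the scatter) from compound 1 to compound 2 and a 50-fold higher number (1.70 log units; beyond the scatter) from compound 3 to compound 4, 50-fold (1.70 log units) apart, beyond the scatter of two such steps Read the other way, chloro in place of bromo gives no change at the digits printed from compound 2 to compound 4 (within the scatter) with phenyl present, whereas with methoxy present it gives a 50-fold lower number from compound 1 to compound 3 (1.70 log units; beyond the scatter), so that step does not carry either: the same change on two cores in this assay, a 50-fold lower number (1.70 log units; beyond the scatter) from compound 1 to compound 3 and no change at the digits printed (within the scatter) from compound 2 to compound 4, 50-fold (1.70 log units) apart, beyond the scatter of two such steps Compounds 1, 2 and 4 share one printed number and only compound 3 stands apart from them, which shows that the lower number needs chloro and methoxy together in this set of four, but does not show why, or whether this holds outside these compounds.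

Going by these compounds, it remains open whether the lower number survives with fluoro in place of chloro on the core of compound 3. On these data alone, it also remains open what an ethoxy, a hydroxy or an amine would do in place of methoxy.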